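This account rests on a few compounds, and the source may have more. Where it says the series, first, only, none or still open, it means among the compounds named here.

Measured in a functional assay on Fem-X cells (Homo sapiens) for cytotoxicity, read by MTT assay, with a stated time of 72 h; on this read-out lower numbers stand for stronger inhibition and higher numbers for weaker inhibition:
- compound 1 `COc1ccc(Nc2cc(-c3cccc(C(F)(F)F)c3)ccn2)cc1`: 68000 nM
- compound 2 `CCc1ccc(Nc2nc3ccccc3cc2-c2ccccc2)cc1`: 92000 nM

In this assay, compound 2 at 92000 nM lies within the scatter of compound 1 at 68000 nM, so the two numbers do not separate. Both are high on this read-out.

The next compound to be measured is compound 3 `COc1cccc(Nc2nc3ccccc3cc2-c2ccccc2)c1`. It carries 3-methoxyphenyl in place of 4-ethylphenyl on a nitrogen on an aromatic ring. The rest of the structure is that of compound 2.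

For the measured compounds named here, no measured step shows what such a change does, so the only guide is the level of compound 2 at 92000 nM. No step beyond the scatter is expected, in either direction. The expected step of a 1.3-fold lower number from compound 2 to compound 3 (0.12 log units; within the scatter) is small. Compound 3 is estimated at 70000 nM, with an expected range of 25000 nM to 150000 nM.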

Compound 3, half-maximal inhibitory concentration: 129000 nM
For compound 3 the middle estimate is 1.8-fold (0.27 log units) below the measured one; measured number inside the range.
By their numbers in this assay, from the lowest: compounds 1, 2 and 3 (each within the scatter of the next).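

For the compounds shown here, at the nitrogen on an aromatic ring, 3-methoxyphenyl in place of 4-ethylphenyl gives in this assay the first readable step, a 1.4-fold higher number from compound 2 to compound 3 (0.15 log units; within the scatter), so the two numbers do not separate. The exchange keeps the count of heavy atoms and brings in an oxygen and a hydrogen-bond acceptor, and this single change produces no shift that can be told from the scatter. No measurement at hand explains this result.

Still open, on these data alone, is whether an amine or a carboxylic acid on this phenyl ring would produce a step beyond the scatter. Going by these compounds alone, with only this one step at the position, it also remains unknown whether any group there can bring the number down from the high level seen for compound 2 and compound 3.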